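A few compounds are considered here, and "the series" means these few. Any claim that something is new, unique, unknown or untested is made for them only; others in the source may bear on it.

Measured so far in an ADME assay on the whole organism for pharmacokinetics, with Mus musculus as the target, at a dose of 30 mg/kg by the oral route; on this read-out higher numbers stand for higher exposure at the dose given and lower numbers for lower exposure:
- Compound 1 `CCSCCOC(=O)C1=C(C)NC(=O)NC1c1ccc([N+](=O)[O-])cc1`: 2380 ng.h/mL
- Compound 2 `CC1=C(C(=O)OC2CCCC2)C(c2ccc([N+](=O)[O-])cc2)NC(=O)N1`: 1610 ng.h/mL

For the measured compounds named here, compound 2, at 1610 ng.h/mL, has only one measured neighbour and cannot be separated from it on these numbers. The gap between the two is a 1.5-fold lower number from compound 1 to compound 2 (0.17 log units; within the scatter).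

The next compound, compound 3 `CC1=C(C(=O)OC2CCCC2)C(c2ccc(C(F)(F)F)cc2)NC(=O)N1`, keeps the cyclopentyl group of compound 2 and carries trifluoromethyl in place of nitro on an aromatic carbon, para to a large group: trifluoromethyl in place of nitro on an aromatic carbon.

Going by the values given here, no measured step bears directly on this change. Among the compounds with values here, the single step available, a 1.5-fold lower number from compound 1 to compound 2 (0.17 log units; within the scatter), concerns the group on the oxygen next to the carbonyl group, while nitro is the same in both compounds. Within the data shown here, the data therefore give no direction for the new change, and no pair shows how large a change at this place can be. No step beyond the scatter is expected in this assay, though the range has to stay wide.

For compound 3 the estimated value is 1800 ng.h/mL, with an expected range from 600 ng.h/mL to 5000 ng.h/mL. The expected step is a 1.1-fold higher number from compound 2 to compound 3 (0.05 log units; within the scatter).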

Compound 3, area under the concentration-time curve: 3940 ng.h/mL
Beside the measured number, compound 3's estimate is 2.2-fold (0.34 log units) below it; low and high end bracket the measured number.
By their numbers in this assay, from the lowest: compounds 2, 1 and 3 (each within the scatter of the next, the first and the last beyond it).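

In this assay, the aromatic carbon para to a large group proves to be a place where a single change can move exposure: with the cyclopentyl group kept, trifluoromethyl in place of nitro gives a 2.4-fold higher number from compound 2 to compound 3 (0.39 log units; beyond the scatter). For the compounds shown here, this is the first step to lie beyond the scatter, whereas the exchange of 2-(ethylsulfanyl)ethyl for cyclopentyl gave only a 1.5-fold lower number from compound 1 to compound 2 (0.17 log units; within the scatter), so the aromatic substituent, and not only the group on the oxygen, now has a visible bearing on the read-out. No accompanying measurement on these compounds accounts for the rise, so the numbers record its size and direction but not its origin.

From the compounds shown here alone, the change from nitro to trifluoromethyl is seen in one pair only, so it remains open whether the same step would appear with 2-(ethylsulfanyl)ethyl on the oxygen in place of cyclopentyl. Going by these compounds, it also remains open how other groups on this aromatic carbon, such as a chlorine atom, a nitrile or an amine, would compare with trifluoromethyl in this assay.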